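Swapping the Bromophenyl Arm for a Dimethoxyphenyl

The source may report more compounds than this note shows. Statements on the series, on what has been measured and on what is new or still open speak of the compounds shown alone.

Compound 1 `Clc1ccc(Nc2ccnc(NCCCNc3ccnc4cc(Cl)ccc34)n2)cc1` and compound 2 `Clc1ccc2c(NCCCNc3nccc(Nc4ccc(Br)cc4)n3)ccnc2c1` share one core and differ only at the aryl amine at one end. In an ADME assay on Vero cells (Chlorocebus sabaeus) for cytotoxicity, read by neutral red uptake, with a stated time of 72 h (a lower number here means a stronger inhibitor, a higher number a weaker inhibitor), compound 1 gives 13400 nM, and in the same assay compound 2 gives 11200 nM. Going by the values given here, the single measured step, a 1.2-fold lower number from compound 1 to compound 2 (0.08 log units; within the scatter), is too small to call a change, so compound 2 sits beside compound 1 rather than apart from it.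

Compound 3 `COc1cc(Nc2ccnc(NCCCNc3ccnc4cc(Cl)ccc34)n2)cc(OC)c1` carries a different change: 3,5-dimethoxyphenyl in place of 4-bromophenyl on a nitrogen on an aromatic ring. Among the compounds with values here, no measured step touches this change; the only step in hand concerns a halogen swap and says nothing about replacing the whole aryl group. With no guide, compound 3 is expected to stay near compound 2, with a step of a 1.1-fold higher number from compound 2 to compound 3 (0.03 log units; within the scatter) and an estimated value of 12000 nM, in the range 4000 nM to 36000 nM.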

Compound 3, half-maximal inhibitory concentration: 12900 nM
Compound 3: middle estimate off by 1.1-fold (0.03 log units), on the low side; measured number inside the range.
By their numbers in this assay, from the lowest: compounds 2, 3 and 1 (each within the scatter of the next).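

The position on the nitrogen on an aromatic ring now has a test larger than a halogen swap. In this assay, 3,5-dimethoxyphenyl in place of 4-bromophenyl gives a 1.2-fold higher number from compound 2 to compound 3 (0.06 log units; within the scatter), and in place of 4-chlorophenyl it gives a 1.0-fold lower number from compound 1 to compound 3 (0.02 log units; within the scatter). Even with a whole aryl group exchanged, one with no halogen and with 2 hydrogen-bond acceptors, the three compounds cannot be told apart in this read-out, and nothing at hand bears on why.

The compounds shown all keep an aromatic carbon ring on this nitrogen, so it remains open whether a group of another kind there, such as a carboxylic acid or an aliphatic amine, would separate from them. From the compounds shown here alone, it is also open whether a longer chain in the linker would do so.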